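Swapping a pyrazole for a piperazine on a shared core

The source may hold more compounds than are shown below. What is called first, only, known or untested is meant among the compounds shown, and "the series" means these compounds.

Of the compounds shown here, three built on one shared core have been tested in an ADME assay on THP-1 cells (Homo sapiens) for cytotoxicity, read by MTT assay, with a stated time of 72 h; a lower number here means that less compound is needed, a higher number that more compound is needed for the effect. Compound 1 `Cc1ccncc1-c1ccc2[nH]c(=O)nc(-c3ccccc3)c2c1` gives > 50000 nM, which is a limit of the assay and not a number. Compound 2 `O=c1nc(-c2ccccc2)c2cc(-c3cccc(F)c3)ccc2[nH]1` gives > 50000 nM, again only a limit. Compound 3 `O=c1nc(-c2ccccc2)c2cc(-c3cc[nH]n3)ccc2[nH]1` gives > 50000 nM, once more a limit. Compound 3 therefore stands at the limit of > 50000 nM in this assay, at which 3 of the 3 values shown sit, the same position as its two companions.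

The steps between these compounds cannot be sized: a step that the two limits leave unreadable from compound 1 to compound 2, a step that the two limits leave unreadable from compound 1 to compound 3 and a step that the two limits leave unreadable from compound 2 to compound 3 all run between two limits, so no direction or magnitude can be read from them.

Compound 4 `O=c1nc(-c2ccccc2)c2cc(N3CCNCC3)ccc2[nH]1` has not yet been measured. The change from compound 3 is piperazin-1-yl in place of 1H-pyrazol-3-yl on an aromatic carbon. Going by the values given here, all three measured steps bear on this change only in the sense that every variation at this position so far left the value at the limit, and none of them gives a readable size. The expectation for the step of a number no higher from compound 3 to compound 4 (the limit leaves the size open) is therefore that it stays within the scatter, with compound 4 most likely again reported as a limit.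

Compound 4 is estimated at 50000 nM, with a range from 20000 nM to 100000 nM.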

Compound 4, half-maximal effective concentration: > 25000 nM
Compound 4 ended at the assay's limit; the forecaster's own chance of this, stated with the estimate: 75%; the middle value is on the limit's open side.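

In this assay compound 4 gives > 25000 nM, which is a limit of the assay and not a number. Its steps from compound 1, compound 2 and compound 3 all run between two limits, so none can be read. The compounds shown leave open whether 4-methylpyridin-3-yl, 3-fluorophenyl, 1H-pyrazol-3-yl and piperazin-1-yl differ at all in this assay.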